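The source may report more compounds than this note shows. Statements on the series, on what has been measured and on what is new or still open speak of the compounds shown alone.

Measured so far:
- compound 1, `NCCCO/N=C\c1ccc(F)cc1`: 2 nM
- compound 2, `NCCCO/N=C\c1cccc(C(=O)O)c1`: 2 nM

In a functional assay on U-251 cells (Homo sapiens) for cytotoxicity, read by WST assay, with a stated time of 24 h (a higher number here means a weaker inhibitor, a lower number a stronger inhibitor), compound 1 gives 2 nM and compound 2 gives 2 nM; the two stand level at the digits shown, within the scatter, so compound 2 marks the same point as compound 1. Compound 3, `CC(=O)NCCCO/N=C\c1cccc(C(=O)O)c1`, differs from compound 2 by acetyl in place of hydrogen on an amine nitrogen. Within the data shown here, no measured pair carries this change, so the series gives no size for it. A modest weakening is expected, and the step of a 3.0-fold higher number from compound 2 to compound 3 (0.48 log units; beyond the scatter) is the estimate. Compound 3 is expected to give 6 nM in this assay, within 1.5 nM to 30 nM.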

Compound 3, half-maximal inhibitory concentration: 2 nM
Beside the measured number, compound 3's estimate is 3.0-fold (0.48 log units) above it, within the range that was stated.
By their numbers in this assay, from the lowest: compounds 1, 2 and 3 (each within the scatter of the next).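

In this assay, acetyl in place of hydrogen on an amine nitrogen brings no change at the digits printed from compound 2 to compound 3 (within the scatter). In this one pair, then, the hydrogen on this nitrogen can give way to acetyl with the level held, so amino to acetamido registers no size at this position. Nothing available accounts for this result.

The compounds shown leave open whether a benzoyl group, a sulfonamide or a dimethylamino group on this nitrogen would hold the same level. Also open, from the compounds shown here alone, is whether acetyl reads the same on compound 1.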